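A few compounds are considered here, and "the series" means these few. Any claim that something is new, unique, unknown or untested is made for them only; others in the source may bear on it.

Compound 1 `Cc1cc(CCC#N)cc(C)c1Oc1cc(Nc2ccc(C#N)cc2)c(N)cc1C(F)(F)F` is the starting point. In an ADME assay on TZM cells (Homo sapiens) for cytotoxicity, read by XTT assay, with a stated time of 4 days (a higher number here means that more compound is tolerated, a lower number that less compound is tolerated), compound 1 gives > 7100 nM, which is a limit of the assay rather than a number (the limit of > 7100 nM in this assay, at which 1 of the 3 values shown sits). Compound 2 `Cc1cc(/C=C/C#N)cc(C)c1Oc1cc(Nc2ccc(C#N)cc2)c(N)cc1C(F)(F)F` gives 15000 nM in this assay. Compound 3 `CC(=O)/C=C/c1cc(C)c(Oc2cc(Nc3ccc(C#N)cc3)c(N)cc2C(F)(F)F)c(C)c1` gives > 8600 nM in this assay, and this too is a limit (the limit of > 8600 nM in this assay, at which 1 of the 3 values shown sits). The steps among these three, a step that the limit leaves unreadable from compound 1 to compound 2, a step that the two limits leave unreadable from compound 1 to compound 3 and a step that the limit leaves unreadable from compound 2 to compound 3, cannot be read in size, so compound 1 stands only as a limit among values of which none shows a readable difference from the others.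

Compound 4 `COC(=O)c1cc(N)c(Nc2ccc(C#N)cc2)cc1Oc1c(C)cc(CCC#N)cc1C` differs from compound 1 by methoxycarbonyl in place of trifluoromethyl on an aromatic carbon. All three measured steps concern the 2-cyanoethyl chain and what replaces it, so none of them bears on this change. Going by the values given here, with no measured step to draw on, no shift beyond the scatter in this assay is expected, since compound 1 itself is only a limit at > 7100 nM. Compound 4 is expected to give 12000 nM in this assay, in a range from 4000 nM to 40000 nM. The expected step is a step that the limit leaves unreadable from compound 1 to compound 4.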

Compound 4, half-maximal cytotoxic concentration in the TZM assay: > 22700 nM
Compound 4 was reported as a limit (the forecaster's own chance of this, stated with the estimate: 60%); middle value at least 1.8-fold (0.27 log units) from the limit.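

Going by these compounds alone, compound 1 and compound 4 both stand as limits in the TZM assay, so no step between them can be read there. In a physicochemical assay for solubility, with a stated time of 4 h, at pH 7.4 (on this read-out lower numbers stand for lower solubility and higher numbers for higher solubility), compound 1 gives 0.24 ug/mL and compound 4 gives 1.21 ug/mL (a 5.0-fold higher number from compound 1 to compound 4 (0.70 log units; beyond the scatter)). The compounds shown leave open whether methoxycarbonyl in place of trifluoromethyl shifts the result in the TZM assay at all.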